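Methoxy Added to Compound 3: An Estimate

This account rests on a few compounds, and the source may have more. Where it says the series, first, only, none or still open, it means among the compounds named here.

Compound 1 `O=S(=O)(c1ccc(C(F)(F)F)cc1)N(CCCN1CCN(c2ccccc2)CC1)CC1CCCCC1`: 456 nM
Compound 2 `O=[N+]([O-])c1ccc(S(=O)(=O)N(CCCN2CCN(c3ccccc3)CC2)CC2CCCCC2)cc1`: 87 nM
Compound 3 `O=S(=O)(c1ccc2ccccc2c1)N(CCCN1CCN(c2ccccc2)CC1)CC1CCCCC1`: 1240 nM

In an assay on CHO cells for displacement of a labelled ligand from 5-hydroxytryptamine receptor 7 (Homo sapiens) (a lower number here means a stronger inhibitor, a higher number a weaker inhibitor), compound 3 stands highest of the three, as a 2.7-fold higher number from compound 1 to compound 3 (0.43 log units; beyond the scatter) and a 14-fold higher number from compound 2 to compound 3 (1.15 log units; beyond the scatter) show. Compound 4 `COc1ccccc1N1CCN(CCCN(CC2CCCCC2)S(=O)(=O)c2ccc3ccccc3c2)CC1` differs from compound 3 by methoxy in place of hydrogen on an aromatic carbon. Among the compounds with values here, none of the measured steps touches this part of the molecule: a 5.2-fold lower number from compound 1 to compound 2 (0.72 log units; beyond the scatter) and the two steps ending at compound 3 all change the group on the sulfonyl sulfur, so they offer no guide to a change on the other end. With nothing to build on, the expected step is none beyond the scatter, a 1.0-fold lower number from compound 3 to compound 4 (0.01 log units; within the scatter). Compound 4 is therefore estimated at 1200 nM, with a range from 350 nM to 4000 nM.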

Compound 4, half-maximal inhibitory concentration: 500 nM
The estimate for compound 4 lay 2.4-fold (0.38 log units) above the measured number; low and high end bracket the measured number.
By their numbers in this assay, from the lowest: compound 2; then compounds 1 and 4 (each within the scatter of the next); then compound 3.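

In this assay the change from phenyl to 2-methoxyphenyl gives a 2.5-fold lower number from compound 3 to compound 4 (0.39 log units; beyond the scatter) and so counts as a real shift, the first seen away from the sulfonyl sulfur. It shows that this end of the molecule also moves the number, and that methoxy ortho to a large group can lower it. Nothing measured here explains the shift.

From the compounds shown here alone, whether the step carries over to compound 1 or compound 2 stays open. So does the outcome with ethoxy, chlorine or an amine at this place.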